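Hydrogen for methyl on the ring amine of compound 2

The source may hold more compounds than are shown below. What is called first, only, known or untested is meant among the compounds shown, and "the series" means these compounds.

Measured so far in a functional assay on the whole organism with Mus musculus as the target, in the hot plate test; on this read-out lower numbers stand for an effect already at smaller amounts and higher numbers for an effect only at larger amounts of compound:
compound 1 `CC(=O)N1CCC(Sc2c[nH]c3ccc(Br)cc23)CC1` gives 2.8 mg/kg
compound 2 `CN1CCC(S(=O)(=O)c2c[nH]c3ccc(Cl)cc23)CC1` gives 16 mg/kg

Compound 2 stands at the higher of the two numbers; its gap to compound 1 lies beyond the scatter, and the two structures differ in more than one place, so only the two values themselves are read. Compound 3 `O=S(=O)(c1c[nH]c2ccc(Cl)cc12)C1CCNCC1` differs from compound 2 by hydrogen in place of methyl on an amine nitrogen in a ring. Within the data shown here, no measured pair isolates this change, so the step from compound 2 to compound 3 is expected to be no change at the digits printed from compound 2 to compound 3 (within the scatter) in this assay, within the scatter. Compound 3 is therefore estimated at 16 mg/kg, with a range from 6 mg/kg to 40 mg/kg.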

Compound 3, dose for half-maximal effect: 8.4 mg/kg
Compound 3: the middle estimate sits 1.9-fold (0.28 log units) above what was measured; low and high end bracket the measured number.
By their numbers in this assay, from the lowest: compound 1; then compounds 3 and 2 (each within the scatter of the next).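

In this assay, among these compounds, this is the first step that isolates a single change: a 1.9-fold lower number from compound 2 to compound 3 (0.28 log units; within the scatter). On the amine nitrogen of the six-membered non-aromatic ring, the read-out therefore does not separate hydrogen from methyl, so neither group stands out at this position. No measurement on hand accounts for this result.

Still open, as far as these compounds go, is how a longer chain or a benzyl group on this nitrogen would read. From the compounds shown here alone, it is also open whether the same step would read alike with the sulfonyl link or the chlorine of compound 3 replaced.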